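Benzyl in place of methyl on the ring nitrogen

A few compounds are considered here, and "the series" means these few. Any claim that something is new, unique, unknown or untested is made for them only; others in the source may bear on it.

Measured so far:
compound 1 `N#Cc1c(-c2ccccc2)nc(SCC(=O)Nn2c(COc3ccc(Cl)cc3Cl)nc3ccccc3c2=O)[nH]c1=O` gives 86%
compound 2 `Cn1c(SCC(=O)Nn2c(COc3ccc(Cl)cc3Cl)nc3ccccc3c2=O)nc(-c2ccccc2)c(C#N)c1=O` gives 59.7%

In a functional assay on the whole organism (strain albino) for inhibition, with Rattus norvegicus as the target, read by paw edema, with stated times of 1 h and 3 h, at a dose of 100 mg/kg by the oral route (a higher number here means a stronger effect of the compound at the dose given, a lower number a weaker effect), compound 2 stands lowest of the two numbers measured, with compound 1 the nearest at a number higher beyond the scatter. For the measured compounds named here, the one step measured, a number 26.3 percentage points lower from compound 1 to compound 2 (beyond the scatter), came from methyl in place of hydrogen on an aromatic nitrogen; it is a modest drop and it is the only step that bears on the next change, and only indirectly.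

Compound 3 `N#Cc1c(-c2ccccc2)nc(SCC(=O)Nn2c(COc3ccc(Cl)cc3Cl)nc3ccccc3c2=O)n(Cc2ccccc2)c1=O` differs from compound 2 by phenyl in place of hydrogen on a saturated chain carbon bound to an aromatic nitrogen. Going by the values given here, no measured pair shows phenyl entering at such a position, so the direction of the step is not fixed by the data; the one measured step suggests that growth at the aromatic nitrogen has so far lowered the number, and the expectation for a number 7.7 percentage points lower from compound 2 to compound 3 (within the scatter) is therefore a small decrease that may well stay within the scatter. For compound 3 the estimate is 52%, with a range from 30% to 72%.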

Compound 3, a percentage reported as inhibition, in the whole organism at one dose (the size of the read-out at that dose, not a potency): 79%
Beside the measured number, compound 3's estimate is 27 percentage points below it; the measured number lies above the stated range.
By their numbers in this assay, from the lowest: compound 2; then compounds 3 and 1 (each within the scatter of the next).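

In this assay, phenyl in place of hydrogen on a saturated chain carbon bound to an aromatic nitrogen gives a number 19.3 percentage points higher from compound 2 to compound 3 (beyond the scatter), so growth at this nitrogen does not simply lower the number, as the earlier pair alone might have suggested. Replacing the hydrogen on this nitrogen with benzyl gives a number 7 percentage points lower from compound 1 to compound 3 (within the scatter), so that hydrogen is not needed to keep the read-out at this dose, while methyl, as in compound 2, stands apart from both. Nothing available explains why benzyl and methyl part in this way.

Still open, on these data alone, is whether the phenyl ring itself matters or only the size of the group, which cyclohexylmethyl or ethyl on the same nitrogen would help separate. A longer chain such as phenethyl, or an amine or carboxylic acid on the benzyl ring, could show how much change this position tolerates.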